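The source may hold more compounds than are shown below. What is called first, only, known or untested is meant among the compounds shown, and "the series" means these compounds.

Compound 3 `COC(=O)/C=C/C(=O)N[C@@H](C)Cn1ccc(-c2ccc(C#N)c(Cl)c2)n1` gives 2460 nM in a functional assay on LNCaP cells (Homo sapiens) for antiproliferative activity, read by CCK-8 assay, with a stated time of 6 days (on this read-out lower numbers stand for stronger inhibition and higher numbers for weaker inhibition), the lowest of the three numbers, although compound 2 `COc1ccc(C(=O)N[C@@H](C)Cn2ccc(-c3ccc(C#N)c(Cl)c3)n2)cc1` with 3410 nM and compound 1 `CC(=O)c1ccc(C(=O)N[C@@H](C)Cn2ccc(-c3ccc(C#N)c(Cl)c3)n2)cc1` with 3600 nM both lie within the scatter of it. Compound 4 `C[C@@H](Cn1ccc(-c2ccc(C#N)c(Cl)c2)n1)NS(=O)(=O)c1cccnc1` differs from compound 3 in one place: (pyridin-3-yl)sulfonyl in place of (2-(methoxycarbonyl)ethenyl)carbonyl on an amine nitrogen. The measured steps all vary the group carried by this same amine nitrogen: a 1.1-fold lower number from compound 1 to compound 2 (0.02 log units; within the scatter), a 1.5-fold lower number from compound 1 to compound 3 (0.17 log units; within the scatter) and a 1.4-fold lower number from compound 2 to compound 3 (0.14 log units; within the scatter), each within the scatter. None of them introduces a sulfonyl or a pyridine ring, so the change in compound 4 goes beyond what has been tried. Since every measured exchange at this place left the number within the scatter, the step is expected to be a 1.0-fold higher number from compound 3 to compound 4 (0.01 log units; within the scatter). Compound 4 is therefore estimated at 2500 nM, between 800 nM and 8000 nM.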

Compound 4, half-maximal inhibitory concentration: 6140 nM
Compound 4: middle estimate off by 2.5-fold (0.39 log units), on the low side; the range from low to high includes it.
By their numbers in this assay, from the lowest: compounds 3, 2, 1 and 4 (each within the scatter of the next, the first and the last beyond it).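

Within the data shown here, the step of a 2.5-fold higher number from compound 3 to compound 4 (0.40 log units; beyond the scatter) is the first at this amine nitrogen printed as beyond the scatter, so the group held here can shift the number, though only modestly. Compound 4 still lies within the scatter of compound 1, so the shift shows only against compound 3. No measurement given here explains the step. Going by these compounds, the sulfonyl and the pyridine ring enter together, so their shares stay open. A phenylsulfonyl group on this nitrogen would separate them, and the effect of a carboxylic acid here is also unknown.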